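The source may report more compounds than this note shows. Statements on the series, on what has been measured and on what is new or still open speak of the compounds shown alone.

Values in an assay on cell membranes for binding affinity to Sigma non-opioid intracellular receptor 1 (Rattus norvegicus) (on this read-out higher numbers stand for weaker inhibition and lower numbers for stronger inhibition), for the three measured compounds:
compound 1, `CCCOc1cccc(N2CCN(CCCN3C(=O)CCc4c(Cl)cccc43)CC2)c1`, gives 370 nM.
compound 2, `O=C1CCc2c(Cl)cccc2N1CCCN1CCN(c2cccc([N+](=O)[O-])c2)CC1`, gives 390 nM.
compound 3, `Nc1cccc(N2CCN(CCCN3C(=O)CCc4c(Cl)cccc43)CC2)c1`, gives 710 nM.

Compound 3 has the highest of the three numbers, but a 1.9-fold higher number from compound 1 to compound 3 (0.28 log units; within the scatter) and a 1.8-fold higher number from compound 2 to compound 3 (0.26 log units; within the scatter) both sit within the scatter, as does a 1.1-fold higher number from compound 1 to compound 2 (0.02 log units; within the scatter), so the three measured compounds read as a single level in this assay rather than as a trend.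

Compound 4 is `CC(=O)Nc1cccc(N2CCN(CCCN3C(=O)CCc4c(Cl)cccc43)CC2)c1`. The change from compound 3 is acetyl in place of hydrogen on a nitrogen on an aromatic ring. Going by the values given here, none of the measured steps touches this nitrogen: each of them swaps one group for another on an aromatic carbon of the shared core, and each of those swaps, across propoxy, nitro and amino, stayed within the scatter. Among the compounds with values here, no step on the amino group itself is available, so the expectation rests on the flatness of the series as a whole. An acetyl on that nitrogen is expected to leave the number at the same level, with no step beyond the scatter in either direction.

Compound 4 is therefore estimated at 650 nM in this assay, within a range of 250 nM to 1700 nM, which means an expected step of a 1.1-fold lower number from compound 3 to compound 4 (0.04 log units; within the scatter).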

Compound 4, half-maximal inhibitory concentration: 670 nM
For compound 4 the middle estimate is 1.0-fold (0.01 log units) below the measured one; low and high end bracket the measured number.
By their numbers in this assay, from the lowest: compounds 1, 2, 4 and 3 (each within the scatter of the next).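

In this assay, going by these compounds alone, the acetyl on this nitrogen gives the first step on the nitrogen itself, a 1.1-fold lower number from compound 3 to compound 4 (0.03 log units; within the scatter), so replacing the hydrogen with a group of 3 heavy atoms, carrying a carbonyl, leaves the number level. The resulting acetamido group also stays level with the two other groups on that aromatic carbon, with a 1.7-fold higher number from compound 2 to compound 4 (0.24 log units; within the scatter) and a 1.8-fold higher number from compound 1 to compound 4 (0.26 log units; within the scatter), which extends the flat reading to propoxy, nitro, amino and acetamido in these four compounds. No evidence is available on why the number responds so little to this change.

Within the data shown here, still open is whether a larger acyl group such as benzoyl, a methanesulfonyl group on the same nitrogen, or a carboxylic acid on the aromatic carbon would stay at this level or produce the first step beyond the scatter. All four compounds share one core, so these values also leave open whether the flat reading would hold with a longer chain in the linker or with fluoro in place of the chloro group.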